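The compounds below may be only part of what the source reports. "The series", "measured", "known", "first", "only" and "open" are said of these compounds alone.

Measured in a functional assay on NCI-H460 cells (Homo sapiens) for cytotoxicity, read by MTT assay, with a stated time of 48 h; on this read-out higher numbers stand for weaker inhibition and lower numbers for stronger inhibition:
- Compound 1 `COc1cc(OC)c(/C=C/C(=O)/C=C/c2cc3ccccc3nc2Cl)c(OC)c1`: > 10000 nM
- Compound 2 `COc1ccc(OC)c(/C=C/C(=O)/C=C/c2cc3ccccc3nc2Oc2cccc(Cl)c2)c1`: > 10000 nM

Compound 2 gives > 10000 nM in this assay, which is a limit and not a number. Among the compounds with values here, compound 2 therefore has no measured potency to build on, and the series so far reads: the limit of > 10000 nM in this assay, at which 2 of the 2 values shown sit.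

Next in the series is compound 3 `COc1cc(OC)c(/C=C/C(=O)/C=C/c2cc3ccccc3nc2Oc2cccc(Cl)c2)c(OC)c1`, not yet measured. The change from compound 2 is 2,4,6-trimethoxyphenyl in place of 2,5-dimethoxyphenyl on a double-bonded chain carbon bound to a double-bonded chain carbon.

Within the data shown here, no measured step in this assay gives a size for this change. Compound 1 also carries 2,4,6-trimethoxyphenyl and gives > 10000 nM, also a limit. Little change is therefore expected, at most a modest gain in inhibition, and another limit is quite possible. The expected change is an at least 1.2-fold lower number from compound 2 to compound 3 (0.09 log units; that floor lies within the scatter). For compound 3 the estimate is 8000 nM, with an expected range of 2500 nM to 25000 nM.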

Compound 3, half-maximal inhibitory concentration: > 10000 nM
Compound 3: a limit, no number; the forecaster's own chance of this, stated with the estimate: 55%; middle value at least 1.2-fold (0.09 log units) from the limit.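

In this assay compound 3 gives only a limit, so neither its step from compound 2 nor its step from compound 1 can be read: the limit of > 10000 nM in this assay, at which 3 of the 3 values shown sit.

The compounds shown leave open which change on the shared core, if any, would yield a measurable potency.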